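The source may hold more compounds than are shown below. What is called first, only, known or untested is meant among the compounds shown, and "the series" means these compounds.

Three compounds share one core and differ only in the ring attached to the five-membered aromatic ring with 2 nitrogen. Compound 1 `COc1ccccc1-n1nc([C@@H]2CCO[C@H](C(C)C)C2)cc1-c1ccc(Cl)cc1` gives 7 nM in an assay on HEK293 cells for inhibition of Voltage-dependent N-type calcium channel subunit alpha-1B (Homo sapiens), read by fluorescence and calcium flux, with a stated time of 5 min; on this read-out lower numbers stand for stronger inhibition and higher numbers for weaker inhibition. Compound 2 `COc1ccccc1-n1nc(C2CCOC(C)(C)C2)cc1-c1ccc(Cl)cc1` gives 2 nM in this assay, and compound 3 `COc1ccccc1-n1nc(C2=CC(C)(C)OC(C)(C)C2)cc1-c1ccc(Cl)cc1` gives 3 nM in this assay. Compound 3 thus holds the second highest of the three numbers: its step to compound 2, a 1.5-fold higher number from compound 2 to compound 3 (0.18 log units; within the scatter), stays within the scatter, while the step from the isopropyl-bearing ring, a 2.3-fold lower number from compound 1 to compound 3 (0.37 log units; beyond the scatter), lies beyond it.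

Compound 4 `COc1ccccc1-n1nc([C@H]2C[C@@H](C)O[C@@H](C)C2)cc1-c1ccc(Cl)cc1` is the next case. Relative to compound 3 the change is a group of 8 heavy atoms (7 carbon, 1 oxygen; one six-membered non-aromatic ring with 1 hetero atom) in place of a group of 10 heavy atoms (9 carbon, 1 oxygen; one six-membered non-aromatic ring with 1 hetero atom), on an aromatic carbon. The group that leaves carries one double bond outside aromatic rings; the group that enters is saturated and bears 3 defined stereocentres.

The step that bears most on this is a 1.5-fold higher number from compound 2 to compound 3 (0.18 log units; within the scatter), where a group of 8 heavy atoms of the same ring class gave a number within the scatter of compound 3. For the measured compounds named here, nothing among the measured compounds points to a step beyond the scatter for compound 4, so the expected change is only a 1.2-fold lower number from compound 3 to compound 4 (0.08 log units; within the scatter). Compound 4 is therefore estimated at 2.5 nM, with a range from 1 nM to 7 nM.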

Compound 4, half-maximal inhibitory concentration: 3 nM
Beside the measured number, compound 4's estimate is 1.2-fold (0.08 log units) below it, within the range that was stated.
By their numbers in this assay, from the lowest: compounds 2, 3 and 4 (each within the scatter of the next); then compound 1.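

In this assay, the saturated 2,6-dimethyloxan-4-yl group, with its 3 defined stereocentres, replaces the larger ring with one double bond in no change at the digits printed from compound 3 to compound 4 (within the scatter), and replaces 2,2-dimethyloxan-4-yl in a 1.5-fold higher number from compound 2 to compound 4 (0.18 log units; within the scatter), so at this aromatic carbon neither change separates the compounds beyond the scatter. The 2-isopropyloxan-4-yl group, by contrast, now stands apart from a third partner, a 2.3-fold lower number from compound 1 to compound 4 (0.37 log units; beyond the scatter), which leaves compound 1 as the only one of the four whose number lies beyond the scatter of the others, while compounds 2, 3 and 4 form a single group within it. No measured finding accounts for either the lack of separation among those three compounds or the separation of compound 1.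

The compounds shown leave open whether this position would keep such numbers with an amine or a carboxylic acid on the ring, or with a longer open chain such as n-hexyl in place of the ring. They also leave open whether the arrangement of the 3 defined stereocentres in 2,6-dimethyloxan-4-yl has any bearing on the number in this assay.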